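A few compounds are considered here, and "the series" means these few. Any claim that something is new, unique, unknown or untested is made for them only; others in the source may bear on it.

In a functional assay on HL-60 cells (Homo sapiens) for cytotoxicity, read by CCK-8 assay, with a stated time of 24 h (a higher number here means a weaker inhibitor, a lower number a stronger inhibitor), compound 1 `C=CC(=O)N1C(=O)CC(C)Sc2ccccc21` gives 199000 nM and compound 2 `C=CC(=O)N1C(=O)CC(c2ccc(Br)cc2)Sc2ccccc21` gives 126000 nM while compound 3 `C=CC(=O)N1C(=O)CC(c2cccc(Cl)c2)Sc2ccccc21` gives 93100 nM in the same read-out. Compound 2 lies within the scatter of both other compounds, as the two steps that touch it show: a 1.6-fold lower number from compound 1 to compound 2 (0.20 log units; within the scatter) and a 1.4-fold lower number from compound 2 to compound 3 (0.13 log units; within the scatter). Going by the values given here, the only step beyond the scatter replaces methyl and is modest: a 2.1-fold lower number from compound 1 to compound 3 (0.33 log units; beyond the scatter).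

Next in view is compound 4 `C=CC(=O)N1C(=O)CC(c2ccc([N+](=O)[O-])cc2)Sc2ccccc21`, which differs from compound 2 in one place: nitro in place of bromo on an aromatic carbon with nitro in place of bromo on an aromatic carbon. Among the compounds with values here, no measured compound carries nitro, so the data give no direct precedent. The closest measured change is 3-chlorophenyl in place of 4-bromophenyl, and it gave a 1.4-fold lower number from compound 2 to compound 3 (0.13 log units; within the scatter). On that basis no step beyond the scatter is expected in this assay, and the expected step is a 1.1-fold lower number from compound 2 to compound 4 (0.06 log units; within the scatter) as a rough estimate. For compound 4 the estimated value is 110000 nM with an expected range of 60000 nM to 190000 nM in this estimate.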

Compound 4, half-maximal inhibitory concentration: 107000 nM
Estimate against measurement, compound 4: 1.0-fold (0.01 log units) above, and the stated range covers the measured number.
By their numbers in this assay, from the lowest: compounds 3, 4, 2 and 1 (each within the scatter of the next, the first and the last beyond it).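

On the aromatic carbon para to a large group, in this assay, nitro in place of bromo gives a 1.2-fold lower number from compound 2 to compound 4 (0.07 log units; within the scatter). The earlier steps shown here exchanged the whole group on the saturated ring carbon, whereas this one changes only the group on the aromatic ring: 3 heavy atoms with 2 hydrogen-bond acceptors replace 1 bromine atom, and compound 2 and compound 4 remain within the scatter of each other. No measurement at hand gives a reason for this result.

From the compounds shown here alone, whether an amine or a carboxylic acid on this aromatic carbon would give a step beyond the scatter remains open, as does the effect of a longer chain on the saturated ring carbon. Also open, going by these compounds, is whether these small steps would hold in any read-out other than this assay.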